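The source may hold more compounds than are shown below. What is called first, only, known or untested is meant among the compounds shown, and "the series" means these compounds.

In a functional assay on UACC-257 cells (Homo sapiens) for cytotoxicity, read by sulforhodamine B assay, with a stated time of 48 h, tested at 1 uM (on this read-out lower numbers stand for a stronger effect and higher numbers for a weaker effect at the one concentration tested), the two measured compounds gave these numbers:
compound 1 `COc1cc(C)cc(-c2c(-c3ccnc(-c4ccc(C(C)=O)cc4)c3)cnn2CC#N)c1`: 38%
compound 2 `Cc1cc(O)cc(-c2nn(CC#N)cc2-c2ccnc(-c3ccc(Oc4ccccc4)cc3)c2)c1`: -7%

Compound 1 stands highest of the two, and compound 2 lies a number beyond the scatter lower. Compound 3 `COc1cc(C)cc(-c2c(-c3ccnc(-c4ccc(N(C)C)cc4)c3)cnn2CC#N)c1` differs from compound 1 by a single change, (dimethylamino in place of acetyl on an aromatic carbon). Going by the values given here, no measured pair shows this change, so its effect in this assay is open. Compound 3 is expected to remain close to compound 1, with a number 3 percentage points lower from compound 1 to compound 3 (within the scatter) a step of no settled direction and of about the size of the scatter. Compound 3 is therefore estimated at 35%, within 8% to 62%.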

Compound 3, a percentage reported as activity, at one concentration (the size of the read-out at that concentration, not a potency): 29%
Compound 3: middle estimate off by 6 percentage points, on the high side; low and high end bracket the measured number.
By their numbers in this assay, from the lowest: compound 2; then compounds 3 and 1 (each within the scatter of the next).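

In this assay, dimethylamino in place of acetyl on an aromatic carbon, para to a large group, gives a number 9 percentage points lower from compound 1 to compound 3 (within the scatter). This single pair therefore shows that the read-out stays within the scatter when one of these two groups replaces the other at this position. No available evidence bears on this result.

As far as these compounds go, it remains open whether a carboxylic acid, a morpholine or a longer alkyl chain at this position would also stay close to compound 1. The compounds shown also leave open whether this change would give a similar step on another background.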